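A Small Chain Extension on Compound 2

The source may report more compounds than this note shows. Statements on the series, on what has been measured and on what is new or still open speak of the compounds shown alone.

Compound 1 `COC1=C(C)C(=O)/C(=C(O)/C=C/c2ccc(O)cc2)C(=O)C1(C)C` and compound 2 `COC1=C(C)C(=O)/C(=C(O)/C=C/c2ccc(C)cc2)C(=O)C1(C)C` share one core and differ in a single group on an aromatic carbon. In a functional assay on A549 cells (Homo sapiens) for cytotoxicity (a lower number here means that less compound is needed, a higher number that more compound is needed for the effect), compound 1 gives 3.1 ug/mL and compound 2 gives 4.3 ug/mL so compound 2 stands level with compound 1 on these numbers. Compound 3 `CCc1ccc(/C=C/C(O)=C2/C(=O)C(C)=C(OC)C(C)(C)C2=O)cc1` departs from compound 2 by one small change methyl in place of hydrogen on a saturated chain carbon bound to an aromatic carbon which is methyl in place of hydrogen on a saturated chain carbon bound to an aromatic carbon, turning 4-methylphenyl into 4-ethylphenyl. For the measured compounds named here, the only measured step, with methyl in place of hydroxy on an aromatic carbon, is a 1.4-fold higher number from compound 1 to compound 2 (0.14 log units; within the scatter) and it offers just an indirect guide, since it swapped a different group. No step beyond the scatter is therefore expected in this assay and the estimated step is a 1.0-fold higher number from compound 2 to compound 3 (0.02 log units; within the scatter) for this small change. The expected value for compound 3 is 4.5 ug/mL with an estimated range from 2.2 ug/mL to 9 ug/mL on repeated measurement.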

Compound 3, concentration for half-maximal effect: 6.1 ug/mL
Compound 3: middle estimate off by 1.4-fold (0.13 log units), on the low side; low and high end bracket the measured number.
By their numbers in this assay, from the lowest: compounds 1, 2 and 3 (each within the scatter of the next).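

Going from 4-methylphenyl to 4-ethylphenyl gives a 1.4-fold higher number from compound 2 to compound 3 (0.15 log units; within the scatter) in this assay and so adds a second small group change at this position that stays inside the usual scatter. The wider comparison, ethyl in place of hydroxy on the aromatic carbon, gives a 2.0-fold higher number from compound 1 to compound 3 (0.29 log units; within the scatter) and is also within the scatter, so this assay does not separate hydroxy, methyl and ethyl at this position. No measurement is available that would explain these numbers.

The compounds shown leave open whether a longer chain such as propyl, an amine or a carboxylic acid on this aromatic carbon would give a step beyond the scatter. They also leave open how the numbers respond to changes made elsewhere on the shared core.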